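Methyl on a Ring Nitrogen: Expected Cytotoxicity of Compound 4

A few compounds are considered here, and "the series" means these few. Any claim that something is new, unique, unknown or untested is made for them only; others in the source may bear on it.

Compound 1 `Cc1ccc(-[n+]2noc([O-])c2CN2CCNCC2)cc1` was tested in an ADME assay on HEL cells (Homo sapiens) for cytotoxicity (on this read-out higher numbers stand for lower toxicity in this test and lower numbers for higher toxicity in this test), where compound 1 gives 100 ug/mL. Compound 2 `[O-]c1on[n+](-c2ccc(Cc3ccc(-[n+]4noc([O-])c4CN4CCN(c5cccc(Cl)c5Cl)CC4)cc3)cc2)c1CN1CCN(c2cccc(Cl)c2Cl)CC1`, a far larger molecule built from two copies of the shared core, gives in this assay a value of 100 ug/mL, level with compound 1 at the digits shown and so within the scatter of it. Compound 3 `[O-]c1on[n+](-c2ccc(Cc3ccc(-[n+]4noc([O-])c4CN4CCN(c5cccc(Cl)c5)CC4)cc3)cc2)c1CN1CCN(c2cccc(Cl)c2)CC1` gives in this assay only a limit, >= 20 ug/mL, not a number; this is the limit of >= 20 ug/mL in this assay, at which 1 of the 3 values shown sits. Of the three results, only those of compound 1 and compound 2 are numbers, and neither sits apart from the other.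

Compound 4 `Cc1ccc(-[n+]2noc([O-])c2CN2CCN(C)CC2)cc1` has not yet been measured. It differs from compound 1 in a single place: methyl in place of hydrogen on an amine nitrogen in a ring. Among the compounds with values here, no pair of measured compounds differs in only one place, so no measured step of this kind exists to lean on. A methyl entering in place of a hydrogen on the ring nitrogen is expected to leave the read-out in this assay where compound 1 stands, with no movement beyond the scatter in either direction; the expected step is no change at the digits printed from compound 1 to compound 4 (within the scatter). Compound 4 is therefore estimated at 100 ug/mL, within a range from 50 ug/mL to 200 ug/mL.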

Compound 4, minimum cytotoxic concentration: 100 ug/mL
Compound 4: middle estimate and measured number agree at the digits printed, and the stated range covers the measured number.
By their numbers in this assay, from the lowest: compounds 1, 2 and 4 (each within the scatter of the next).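

In this assay, within the data shown here, the change from piperazin-1-yl to 4-methylpiperazin-1-yl gives the first step that can be read at a single position, and that step is no change at the digits printed from compound 1 to compound 4 (within the scatter) for methyl in place of hydrogen. The earlier compounds shown here could not show this, for no two of them differ in only one place; now there is one direct comparison showing that, on this core, the hydrogen on the amine nitrogen in the ring can give way to a methyl without a shift beyond the scatter. Nothing measured here bears on why the read-out stays put, so this flat step comes without a cause.

From the compounds shown here alone, whether an ethyl group, a longer chain or an acetyl group on the same ring nitrogen would also leave the read-out in place remains open, as one small group says little about others. Compound 2 and compound 3 each differ from compound 1 in more than one place, so neither of them settles that question.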